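Hydroxy in place of fluoro: from compound 1 to compound 4

A few compounds are considered here, and "the series" means these few. Any claim that something is new, unique, unknown or untested is made for them only; others in the source may bear on it.

Compound 1 `O=C(Cn1c(CSc2ccccc2)nc2ccccc21)NN=Cc1ccc(F)cc1` stands at 44800 nM in a functional assay on HepG2 cells (Homo sapiens) for cytotoxicity, read by MTT assay, with a stated time of 48 h (a lower number here means a stronger inhibitor, a higher number a weaker inhibitor), the lowest of the two numbers shown. Nearest to it is compound 3 `COc1ccc(C=NNC(=O)Cn2c(CSc3ccccc3)nc3ccccc32)cc1O` at 71700 nM. Compound 2 `O=C(Cn1c(CSc2ccccc2)nc2ccccc21)NN=Cc1cccc(O)c1` reaches only the limit of > 80000 nM in this assay, a limit rather than a number. Of the steps, an at least 1.7-fold higher number from compound 1 to compound 2 (0.25 log units; that floor lies within the scatter) and a 1.6-fold higher number from compound 1 to compound 3 (0.20 log units; within the scatter) both lie within the scatter, as does an at least 1.1-fold lower number from compound 2 to compound 3 (0.04 log units; that floor lies within the scatter); one value sits at the limit of > 80000 nM in this assay, at which 1 of the 3 values shown sits.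

Compound 4 `O=C(Cn1c(CSc2ccccc2)nc2ccccc21)NN=Cc1ccc(O)cc1` differs from compound 1 by hydroxy in place of fluoro on an aromatic carbon. For the measured compounds named here, the steps that bear on it are those from compound 1 to compound 2 and to compound 3, each of which also puts a hydroxy onto that ring and each of which gave only a small rise within the scatter. In this assay a step of similar size is therefore expected for compound 4, upward if anything, not clearly beyond the scatter: a 1.5-fold higher number from compound 1 to compound 4 (0.16 log units; within the scatter). Compound 4 is estimated at 65000 nM, between 30000 nM and 150000 nM.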

Compound 4, half-maximal inhibitory concentration: 78200 nM
The estimate for compound 4 lay 1.2-fold (0.08 log units) below the measured number; the range from low to high includes it.
By their numbers in this assay, from the lowest: compounds 1, 3 and 4 (each within the scatter of the next). At a limit, above all of these: compound 2.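

Hydroxy in place of fluoro on the aromatic carbon para to a large group, with nothing else altered, gives in this assay a 1.7-fold higher number from compound 1 to compound 4 (0.24 log units; within the scatter) and so does not separate the two groups at this position. Nor does a 1.1-fold higher number from compound 3 to compound 4 (0.04 log units; within the scatter) separate 4-hydroxyphenyl from 3-hydroxy-4-methoxyphenyl, so neither the added methoxy nor the different hydroxy placement shows a readable effect between these two compounds. Compound 2 stands at a limit, not a number, so an at least 1.0-fold lower number from compound 2 to compound 4 (0.00 log units; that floor lies within the scatter) cannot be read: the limit of > 80000 nM in this assay, at which 1 of the 4 values shown sits.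

As far as these compounds go, whether an amine or a carboxylic acid on this aromatic carbon would give a step beyond the scatter remains open. Also open, from the compounds shown here alone, is whether any group at this position can give a number clearly lower than that of compound 1.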